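The source may report more compounds than this note shows. Statements on the series, on what has been measured and on what is new or still open speak of the compounds shown alone.

Measured compounds and their values in a functional assay on CHO cells for agonist activity at Alpha-1A adrenergic receptor (Homo sapiens), read by FLIPR and calcium flux; on this read-out higher numbers stand for larger maximal responses and lower numbers for smaller maximal responses:

compound 1 `COc1c(C)ccc2c1CCC2c1ncc[nH]1` gives 40%
compound 2 `COc1cccc2c1CCC2c1ncc[nH]1` gives 65%
compound 3 `c1ccc2c(c1)CCCC2c1ncc[nH]1` gives 71%

Compound 2 stands near the top of these three numbers. Its closest neighbour is compound 3, whose value lies within the usual scatter of that of compound 2, so nothing separates the two. Within the data shown here, compound 1 is the furthest away, and the one measured step, a number 25 percentage points higher from compound 1 to compound 2 (beyond the scatter), is beyond the scatter, modest in size, and goes with hydrogen in place of methyl on an aromatic carbon.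

The next compound, compound 4 `c1cc(-c2nccs2)c2c(c1)C(c1ncc[nH]1)CC2`, is reached from compound 2 by the change (1,3-thiazol-2-yl in place of methoxy on an aromatic carbon). Among the measured compounds shown here, no measured step touches this change: the step from compound 1 to compound 2 concerns a methyl group, not the methoxy that leaves here, and the pair of compound 2 and compound 3 shows only that the methoxy itself makes no difference beyond the scatter. For the measured compounds named here, compound 4 therefore has no close precedent, and a new ring entering where a small group sat carries wide uncertainty. The expected step in this assay, a number 10 percentage points lower from compound 2 to compound 4 (within the scatter), is a small decrease that may well fall within the scatter.

For compound 4 the estimate in this assay is 55%, with a range from 30% to 80%.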

Compound 4, largest response reached (Emax), in percent of the reference or control that the assay uses: 64%
The estimate for compound 4 lay 9 percentage points below the measured number; low and high end bracket the measured number.
By their numbers in this assay, from the lowest: compound 1; then compounds 4, 2 and 3 (each within the scatter of the next).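

In this assay the exchange of methoxy for 1,3-thiazol-2-yl, on an aromatic carbon ortho to a fused ring, comes with a number 1 percentage points lower from compound 2 to compound 4 (within the scatter) and so leaves no difference that this read-out can separate. Until now this place had been seen carrying only methoxy or, in compound 3, nothing at all, whereas compound 4 shows that it can hold a group of 5 heavy atoms with one five-membered aromatic ring, and that compound 4 keeps a maximal response of 64% with this group in place. Nothing at hand explains why the response holds across this change.

The compounds shown leave open whether this tolerance extends to groups of another kind at the same place, such as an amine, a carboxylic acid or a longer chain, or whether it is particular to an aromatic ring like the 1,3-thiazol-2-yl group. Among these compounds, they also leave open whether 1,3-thiazol-2-yl would give a similar response alongside the methyl group of compound 1, the one change so far that has moved this number beyond the scatter.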